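The source may report more compounds than this note shows. Statements on the series, on what has been measured and on what is new or still open speak of the compounds shown alone.

In an assay on CHO cells for displacement of a labelled ligand from adenosine receptor A3 (Homo sapiens), read by scintillation counting, tested at 10 uM (a higher number here means more inhibition at the concentration tested (going by the name of the read-out), a lower number less inhibition), the three measured compounds gave these numbers:

Compound 1 `CC(C)(C)Cc1csc(N)c1C(=O)c1ccc(Cl)cc1` gives 5%.
Compound 2 `CC(C)(C)Cc1c(-c2ccncc2)sc(N)c1C(=O)c1ccc(Cl)cc1` gives 6%.
Compound 3 `Cc1ccccc1-c1sc(N)c(C(=O)c2ccc(Cl)cc2)c1CC(C)(C)C` gives 1%.

Compound 3 gives the smallest of the three numbers, yet its step from compound 1 (a number 4 percentage points lower from compound 1 to compound 3 (within the scatter)) and from compound 2 (a number 5 percentage points lower from compound 2 to compound 3 (within the scatter)) both lie within the scatter, as does a number 1 percentage points higher from compound 1 to compound 2 (within the scatter). Compound 4 `CC(C)(C)Cc1c(-c2ccsc2)sc(N)c1C(=O)c1ccc(Cl)cc1` is compound 3 with one change: thiophen-3-yl in place of 2-methylphenyl on an aromatic carbon. Within the data shown here, two measured steps bear on this: swapping the aromatic ring at this position, or removing it, left this assay unchanged within the scatter. No step beyond the scatter is therefore expected for compound 4: a number 3 percentage points higher from compound 3 to compound 4 (within the scatter). Compound 4 is estimated at 4%, between -5% and 13%.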

Compound 4, a percentage reported as inhibition, at one concentration (the size of the read-out at that concentration, not a potency): 4%
The estimate for compound 4 equals the measured number at the digits printed, within the range that was stated.
By their numbers in this assay, from the lowest: compounds 3, 4, 1 and 2 (each within the scatter of the next).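

With thiophen-3-yl, a five-membered aromatic ring with 1 sulfur, the position now holds a ring other than a six-membered one, yet this assay gives only small steps: a number 3 percentage points higher from compound 3 to compound 4 (within the scatter), a number 2 percentage points lower from compound 2 to compound 4 (within the scatter) and a number 1 percentage points lower from compound 1 to compound 4 (within the scatter). Ring size and the ring sulfur therefore add no visible change to what the earlier compounds showed. No measurement at hand explains this lack of change.

On these data alone, whether an aminomethyl group or a carboxylic acid on this carbon would shift the number stays open. So does the effect of replacing the neopentyl group or the (4-chlorophenyl)carbonyl group.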